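Removing Trifluoromethoxy from a Weakly Cytotoxic Compound

The compounds below may be only part of what the source reports. "The series", "measured", "known", "first", "only" and "open" are said of these compounds alone.

Measured compounds:
compound 1 (`Clc1nss/c1=N\c1ccc(OCc2ccccc2)cc1`): > 100000 nM
compound 2 (`FC(F)(F)Oc1ccc(/N=c2\ssnc2Cl)cc1Br`): 100000 nM

Both compounds were tested in a functional assay on A-431 cells (Homo sapiens) for cytotoxicity, read by resazurin assay, with a stated time of 72 h; on this read-out lower numbers stand for stronger inhibition and higher numbers for weaker inhibition. For compound 1 the assay returns only a limit, (the limit of > 100000 nM in this assay, at which 1 of the 2 values shown sits), and not a number. Compound 2, in contrast, gives an actual number in this assay, 100000 nM, and so it holds the only real figure among the two values shown, at the weak end of what this assay can report.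

Compound 3 (`Clc1nss/c1=N\c1cccc(Br)c1`) differs from compound 2 by hydrogen in place of trifluoromethoxy on an aromatic carbon. For the measured compounds named here, no step between measured compounds is available to guide this change, so any expectation rests on where compound 2 already stands. The expected step is no change at the digits printed from compound 2 to compound 3 (within the scatter), nothing beyond the usual scatter in either direction. For compound 3 the estimate in this assay is 100000 nM, within a range of 30000 nM to 300000 nM.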

Compound 3, half-maximal inhibitory concentration: > 100000 nM
Compound 3 was reported as a limit; the forecaster's own chance of this, stated with the estimate: 55%; the middle value sits exactly at the limit.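

In this assay, replacing trifluoromethoxy with hydrogen on the aromatic carbon ortho to the bromo group gives a number no lower from compound 2 to compound 3 (the limit leaves the size open), so this change brought no stronger inhibition. Compound 3 gives only a limit, > 100000 nM, and not a number, which means the size of this step cannot be read. Removing the group therefore leaves compound 3 at the weak end of the read-out, where most of the compounds shown now sit: the limit of > 100000 nM in this assay, at which 2 of the 3 values shown sit.

For the compounds shown here, whether an amine or a carboxylic acid on this same aromatic carbon would give a value clearly lower than the one for compound 2, 100000 nM, remains open. Also open, from the compounds shown here alone, is how much weaker compound 3 really is than compound 2, if it is weaker by more than the usual scatter at all.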